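Replacing a Phenolic Hydroxy by Chloro: Expected Cytotoxicity

The source may report more compounds than this note shows. Statements on the series, on what has been measured and on what is new or still open speak of the compounds shown alone.

Compound 1 `COc1ccc(C(=O)/C=C/c2cc3ccccc3[nH]c2=O)cc1` and compound 2 `O=C(/C=C/c1cc2ccccc2[nH]c1=O)c1ccc(O)cc1` share a core and differ only in hydrogen in place of methyl on an oxygen on an aromatic ring. In a functional assay on MDA-MB-435 cells (Homo sapiens) for cytotoxicity, read by sulforhodamine B assay, with a stated time of 24 h (on this read-out lower numbers stand for stronger inhibition of growth and higher numbers for weaker inhibition of growth), compound 1 gives 3920 nM, while compound 2 gives 2940 nM; the step of a 1.3-fold lower number from compound 1 to compound 2 (0.12 log units; within the scatter) lies within the scatter. Compound 2 thus shows the lowest of the two numbers, with compound 1 close to it.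

Compound 3 `O=C(/C=C/c1cc2ccccc2[nH]c1=O)c1ccc(Cl)cc1` carries the change (chloro in place of hydroxy on an aromatic carbon), so that the 4-hydroxyphenyl of compound 2 becomes a 4-chlorophenyl. Within the data shown here, no measured step bears directly on this exchange; the only measured step, from compound 1 to compound 2, concerns the same oxygen and was within the scatter. Compound 3 is therefore expected to lie near compound 2, with a 1.2-fold lower number from compound 2 to compound 3 (0.07 log units; within the scatter) not beyond the scatter. The estimate for compound 3 in this assay is 2500 nM, with a range from 800 nM to 8000 nM.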

Compound 3, concentration for 50% growth inhibition: 2830 nM
The estimate for compound 3 lay 1.1-fold (0.05 log units) below the measured number; the range from low to high includes it.
By their numbers in this assay, from the lowest: compounds 3, 2 and 1 (each within the scatter of the next).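

In this assay, the oxygen at this place, on an aromatic carbon para to a large group, is now removed altogether, giving a 1.0-fold lower number from compound 2 to compound 3 (0.02 log units; within the scatter) and, with chloro in place of methoxy, a 1.4-fold lower number from compound 1 to compound 3 (0.14 log units; within the scatter). The earlier compounds had shown only a change on that oxygen, whereas here hydroxy, counted as 1 hydrogen-bond donor and 1 hydrogen-bond acceptor, gives way to chloro, counted as 0 of each, and all three compounds remain within the scatter of one another. Nothing available explains this result.

The compounds shown leave open how an amine, a carboxylic acid or a longer chain would read at this place. They also leave open whether chloro and hydroxy would stay as close with a change elsewhere on the shared core.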